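The source may report more compounds than this note shows. Statements on the series, on what has been measured and on what is new or still open speak of the compounds shown alone.

Compound 1, `C=C1C(=O)C2=C3[C@H]1[C@H]1OC(=O)C(=C)[C@@H]1CC[C@@]3(O)CC[C@]21C(=O)C[C@H]2C(=C)CC[C@H]3C(=C)C(=O)O[C@@H]3[C@H]21`, was tested in a functional assay on C6 cells (Rattus norvegicus) for cytotoxicity, read by CellTiter-Glo, with a stated time of 72 h; a higher number here means a weaker inhibitor, a lower number a stronger inhibitor. In this assay compound 1 gives > 10000 nM, which is a limit of the assay rather than a number. A second compound, compound 2, `C=C1C(=O)O[C@@H]2[C@@H]3C4=C(C(=O)[C@H]3CO)[C@]3(CC[C@]4(O)CC[C@@H]12)C(=O)C[C@H]1C(=C)CC[C@H]2C(=C)C(=O)O[C@@H]2[C@H]13`, was tested in the same way. In this assay compound 2 gives > 10000 nM, again a limit and not a number. Compound 1 thus stands at the limit of > 10000 nM in this assay, at which 2 of the 2 values shown sit, so no order between the two measured compounds can be read from these results. Compound 3, `C=C1C(=O)C2=C3[C@H](CC[C@H]4C(=C)C(=O)O[C@@H]4[C@@H]13)CC[C@]21C(=O)C[C@H]2C(=C)CC[C@H]3C(=C)C(=O)O[C@@H]3[C@H]21`, has not yet been measured. It differs from compound 1 in one place: hydrogen in place of hydroxy on a saturated ring carbon. Going by the values given here, no step between measured compounds is available here to show what such a change does in this assay. Because compound 1 sits at the limit of > 10000 nM in this assay, at which 2 of the 2 values shown sit, the expected step from compound 1 to compound 3 in this assay is a number no higher from compound 1 to compound 3 (the limit leaves the size open), with no change beyond the usual scatter anticipated. The estimate for compound 3 in this assay is 10000 nM, with a range from 4000 nM to 30000 nM, and the result may well again be reported only as a limit.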

Compound 3, half-maximal inhibitory concentration: > 10000 nM
Compound 3 was reported as a limit (the forecaster's own chance of this, stated with the estimate: 75%); the middle value lies on the limit itself.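

In this assay compound 3 gives > 10000 nM, again a limit and not a number. Going by these compounds alone, compound 1 and compound 3 both end at a limit, so no step between them can be read: the limit of > 10000 nM in this assay, at which 3 of the 3 values shown sit. The compounds shown leave open whether hydrogen in place of hydroxy on a saturated ring carbon changes the result in this assay at all.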